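Trimming one methoxy from the aryl on the saturated ring

A few compounds are considered here, and "the series" means these few. Any claim that something is new, unique, unknown or untested is made for them only; others in the source may bear on it.

Compound 2 `COc1ccc(/C=C/C[C@H]2C[C@@H]([C@@H](O)c3ccc(OC)c(OC)c3)CO[C@@H]2c2ccc(OC)c(OC)c2)cc1OC` carries the highest of the two numbers recorded so far. In a functional assay on HeLa cells (Homo sapiens) for cytotoxicity, read by WST assay, with a stated time of 48 h (on this read-out lower numbers stand for stronger inhibition and higher numbers for weaker inhibition), compound 2 gives 23800 nM, whereas compound 1 `COc1ccc(/C=C/C[C@H]2C[C@@H]([C@@H](O)c3ccc(OC)c(OC)c3)CO[C@@H]2c2ccccc2)cc1OC` gives 17000 nM; the two numbers lie within the scatter of each other. Compound 3 `COc1cccc([C@H]2OC[C@H]([C@@H](O)c3ccc(OC)c(OC)c3)C[C@@H]2C/C=C/c2ccc(OC)c(OC)c2)c1` has not yet been measured; it differs from compound 2 in one place: hydrogen in place of methoxy on an aromatic carbon.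

Going by the values given here, only one measured step bears on this change. Going a 1.4-fold higher number from compound 1 to compound 2 (0.15 log units; within the scatter) exchanged phenyl for 3,4-dimethoxyphenyl on the same saturated ring carbon, and that step stayed within the scatter. Compound 3 keeps one of the two methoxy groups on that ring, so it sits between compound 1 and compound 2 in that respect, and both of those compounds give numbers within the scatter of each other.

Compound 3 is therefore expected to show essentially no change beyond the scatter, a step of a 1.2-fold lower number from compound 2 to compound 3 (0.08 log units; within the scatter) in this assay. The estimate for compound 3 is 20000 nM, with a range from 10000 nM to 45000 nM.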

Compound 3, half-maximal inhibitory concentration: 21800 nM
For compound 3 the middle estimate is 1.1-fold (0.04 log units) below the measured one; the range from low to high includes it.
By their numbers in this assay, from the lowest: compounds 1, 3 and 2 (each within the scatter of the next).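

The third compound fills the gap between the two earlier ones at this aryl group. Removing the methoxy group that stands ortho to a methoxy group and para to a large group gives a step of a 1.1-fold lower number from compound 2 to compound 3 (0.04 log units; within the scatter) in this assay, and adding a single methoxy group to the unsubstituted phenyl gives a step of a 1.3-fold higher number from compound 1 to compound 3 (0.11 log units; within the scatter). Going by these compounds alone, the earlier comparison showed only that adding both methoxy groups together left the number within the scatter, whereas these steps show the same for each single methoxy change tested here, so phenyl, 3-methoxyphenyl and 3,4-dimethoxyphenyl cannot be told apart in this read-out.

On these data alone, whether this tolerance extends to other kinds of substituent remains open, for example an amine, a carboxylic acid or a longer chain such as butoxy on this aryl ring. As far as these compounds go, the three compounds also share the rest of the core, including its hydroxyl group and the alkenyl chain, so what those parts contribute stays unknown. No supporting data are available to explain the result.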